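The source may report more compounds than this note shows. Statements on the series, on what has been measured and on what is new or still open speak of the compounds shown alone.

Compound 1 `CCS(=O)(=O)c1ccc(Nc2ncnc(N3CCC(c4nc(C(C)C)no4)CC3)c2[N+](=O)[O-])cc1`: in a functional assay for agonist activity at Glucose-dependent insulinotropic receptor (Homo sapiens) (a lower number here means that less compound is needed, a higher number that more compound is needed for the effect), compound 1 gives 17 nM.
Compound 2 `CCCS(=O)(=O)c1ccc(Nc2ncnc(N3CCC(c4nc(C(C)C)no4)CC3)c2[N+](=O)[O-])cc1`: compound 2 gives 4.7 nM.
Compound 3 `CCSc1ccc(Nc2ncnc(N3CCC(c4nc(C(C)C)no4)CC3)c2[N+](=O)[O-])cc1`: compound 3 gives 110 nM.

Compound 3 has the highest number of the three: a 6.5-fold higher number from compound 1 to compound 3 (0.81 log units; beyond the scatter) and a 23-fold higher number from compound 2 to compound 3 (1.37 log units; beyond the scatter). Compound 4 `CCS(=O)(=O)c1ccc(Nc2ncnc(N3CCC(c4nc(C(C)C)no4)CC3)c2[N+](=O)[O-])c(F)c1` differs from compound 3 in one place: a group of 12 heavy atoms (8 carbon, 2 oxygen, 1 fluorine, 1 sulfur; one six-membered aromatic ring of carbon only) in place of a group of 9 heavy atoms (8 carbon, 1 sulfur; one six-membered aromatic ring of carbon only), on a nitrogen on an aromatic ring. Part of this change is the reverse of the step seen in a 6.5-fold higher number from compound 1 to compound 3 (0.81 log units; beyond the scatter), so the return to ethylsulfonyl alone would be expected to bring the number back down by about that amount. Going by the values given here, no measured pair shows what the added fluorine does, so this part of the change is left at zero. Compound 4 is therefore expected to give 15 nM, with a range of 5 nM to 50 nM, which is an expected step of a 7.3-fold lower number from compound 3 to compound 4 (0.87 log units; beyond the scatter).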

Compound 4, half-maximal effective concentration: 7 nM
Estimate against measurement, compound 4: 2.1-fold (0.33 log units) above; the range from low to high includes it.
By their numbers in this assay, from the lowest: compounds 2 and 4 (each within the scatter of the next); then compound 1; then compound 3.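

In this assay, fluoro in place of hydrogen on an aromatic carbon gives a 2.4-fold lower number from compound 1 to compound 4 (0.39 log units; beyond the scatter), the first sign that this ring can carry a second group with a gain. The full change on the nitrogen gives a 16-fold lower number from compound 3 to compound 4 (1.20 log units; beyond the scatter), so the sulfonyl and fluoro together more than offset the drop seen with ethylsulfanyl. Against the propylsulfonyl compound there is a 1.5-fold higher number from compound 2 to compound 4 (0.17 log units; within the scatter), so fluoro with the ethyl chain serves about as well as the longer chain alone.

Nothing shown explains these steps. On these data alone, whether fluoro also helps the propylsulfonyl compound, and whether chloro or methoxy can replace it, stays open.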